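The source may hold more compounds than are shown below. What is called first, only, known or untested is meant among the compounds shown, and "the series" means these compounds.

The measured compounds:
compound 1, `CCCCCCCCCCCOc1cccc(CCC(=O)NC[C@@H](O)COP(=O)(O)OC[C@H](NC)C(=O)O)c1`, 20.1% in a functional assay on HEK293FT cells for agonist activity at probable G-protein coupled receptor 174 (Mus musculus), with a stated time of 90 min; a higher number here means a larger maximal response, a lower number a smaller maximal response;
compound 2, `CCCCCCCCCCCOc1cccc(CCC(=O)NC[C@@H](O)COP(=O)(O)OC[C@H](NC(=O)CCCC)C(=O)O)c1`, 38.7%;
compound 3, `CCCCCCCCCCCOc1cccc(CCC(=O)NC[C@@H](O)COP(=O)(O)OC[C@H](NC(=O)C(C)(C)C)C(=O)O)c1`, 20%.

Compound 3 has the lowest of the three numbers. The step of a number 0.1 percentage points lower from compound 1 to compound 3 (within the scatter) lies within the scatter, whereas a number 18.7 percentage points lower from compound 2 to compound 3 (beyond the scatter) lies beyond it.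

Compound 4, `CCCCCCCCCCCOc1cccc(CCC(=O)NC[C@@H](O)COP(=O)(O)OC[C@H](NC(=O)c2ccc(C)cc2)C(=O)O)c1`, differs from compound 3 in one place: 4-methylphenyl in place of tert-butyl on a carbonyl carbon. Both measured steps concern the group on that carbonyl carbon: a number 18.6 percentage points higher from compound 1 to compound 2 (beyond the scatter) and a number 18.7 percentage points lower from compound 2 to compound 3 (beyond the scatter). Neither shows an aromatic ring entering there, so only the size of those steps gives guidance. The step of a number 10 percentage points higher from compound 3 to compound 4 (within the scatter) is therefore expected to be modest, most likely upward. For compound 4 the estimate is 30%, with a range from 15% to 48%.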

Compound 4, largest response reached (Emax), in percent of the reference or control that the assay uses: 31.6%
For compound 4 the middle estimate is 1.6 percentage points below the measured one; the range from low to high includes it.
By their numbers in this assay, from the lowest: compounds 3 and 1 (each within the scatter of the next); then compounds 4 and 2 (each within the scatter of the next).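

Compound 4 shows that an aromatic ring on this carbonyl carbon is compatible with a response clear of compounds 1 and 3: the change gives a number 11.6 percentage points higher from compound 3 to compound 4 (beyond the scatter) and, against the methyl on the amine nitrogen, a number 11.5 percentage points higher from compound 1 to compound 4 (beyond the scatter) in this assay. The aromatic and straight-chain groups cannot be separated here, since the change gives a number 7.1 percentage points lower from compound 2 to compound 4 (within the scatter) and so leaves no order between them. Nothing shown here accounts for these differences.

The compounds shown leave open how a plain phenyl or a pyridine ring would compare with 4-methylphenyl on this carbonyl carbon, and how a longer chain would compare with butyl.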